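This account rests on a few compounds, and the source may have more. Where it says the series, first, only, none or still open, it means among the compounds named here.

Of the compounds shown here, two have been measured in an ADME assay on RAW264.7 cells (Mus musculus) for cytotoxicity, read by MTT assay, with a stated time of 72 h, tested at 50 uM; a lower number here means a weaker effect, a higher number a stronger effect of the compound at the concentration tested: compound 1 `O=C(Cn1c(=O)oc2ccccc21)Nc1cc(C(F)(F)F)ccc1Cl` gives 12.3%, and compound 2 `O=C(Cn1c(=O)oc2cc(Cl)ccc21)Nc1cc(C(F)(F)F)ccc1Cl` gives 1.61%.

Among the measured compounds shown here, compound 2 stands lowest of the two numbers; the only measured step, a number 10.7 percentage points lower from compound 1 to compound 2 (beyond the scatter), separates it from compound 1. Compound 3 `O=C(Cn1c(=O)oc2cc([N+](=O)[O-])ccc21)Nc1cc(C(F)(F)F)ccc1Cl` differs from compound 2 by nitro in place of chloro on an aromatic carbon. For the measured compounds named here, no measured step swaps one substituent for another at this place, so the step from compound 1 to compound 2 bears on it only loosely, and both numbers so far are small. Only a small change is expected, if any beyond the scatter: a number 4.4 percentage points higher from compound 2 to compound 3 (within the scatter). Compound 3 is therefore estimated at 6%, between -5% and 20%.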

Compound 3, a percentage reported as inhibition, at one concentration (the size of the read-out at that concentration, not a potency): 12.8%
The estimate for compound 3 lay 6.8 percentage points below the measured number; measured number inside the range.
By their numbers in this assay, from the lowest: compound 2; then compounds 1 and 3 (each within the scatter of the next).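

In this assay, the group at this position makes a difference: nitro in place of chloro gives a number 11.2 percentage points higher from compound 2 to compound 3 (beyond the scatter) and shows that the low number of compound 2 does not hold for every group placed here. Nitro in place of hydrogen gives a number 0.5 percentage points higher from compound 1 to compound 3 (within the scatter) and so leaves the read-out unchanged within the scatter. Nothing available explains why chloro and nitro differ.

As far as these compounds go, with only chloro and nitro to compare, it remains open whether the lower number is particular to chloro. An amine or a methoxy group at this position could show how other substituents behave.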